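The compounds below may be only part of what the source reports. "The series", "measured", "known", "first", "only" and "open" are said of these compounds alone.

- Compound 1 `C=C1C2=C(C(=O)N1OC)[C@H](OC(=O)CSc1nc3ccccc3o1)[C@@](C)(O)[C@H](CCCCC)O2`: 2600 nM
- Compound 2 `C=C1C2=C(C(=O)N1OC)[C@H](OC(=O)CCCCCl)[C@@](C)(O)[C@H](CCCCC)O2`: 4200 nM

In a functional assay on Jurkat cells (Homo sapiens) for cytotoxicity, read by MTT assay, with a stated time of 72 h (on this read-out lower numbers stand for stronger inhibition and higher numbers for weaker inhibition), compound 2 gives 4200 nM, within the scatter of compound 1. Compound 3 `C=C1C2=C(C(=O)N1OC)[C@H](OC(=O)CSc1nc3ccccc3[nH]1)[C@@](C)(O)[C@H](CCCCC)O2` places (1H-benzimidazol-2-yl)sulfanyl in place of 3-chloropropyl on a saturated chain carbon bound to a carbonyl carbon. For the measured compounds named here, one measured step bears on this, a 1.6-fold higher number from compound 1 to compound 2 (0.21 log units; within the scatter), where 3-chloropropyl replaced (1,3-benzoxazol-2-yl)sulfanyl at that place. It stayed within the scatter, so no change beyond the scatter is expected. The expected step is a 1.4-fold lower number from compound 2 to compound 3 (0.16 log units; within the scatter). For compound 3 the estimated value is 2900 nM, with an expected range of 1200 nM to 7000 nM.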

Compound 3, half-maximal inhibitory concentration: 8900 nM
Beside the measured number, compound 3's estimate is 3.1-fold (0.49 log units) below it; measured number above the stated range.
By their numbers in this assay, from the lowest: compounds 1 and 2 (each within the scatter of the next); then compound 3.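

In this assay the place on a saturated chain carbon bound to a carbonyl carbon now shows a change beyond the scatter: (1H-benzimidazol-2-yl)sulfanyl in place of 3-chloropropyl gives a 2.1-fold higher number from compound 2 to compound 3 (0.33 log units; beyond the scatter) and, on the sulfur, 1H-benzimidazol-2-yl in place of 1,3-benzoxazol-2-yl gives a 3.4-fold higher number from compound 1 to compound 3 (0.53 log units; beyond the scatter) in the same direction. The two heteroaromatic groups on the sulfur are thus not interchangeable here, although compound 1 and compound 2 stood within the scatter of each other. Nothing measured on these compounds accounts for this. Going by these compounds, whether an amine, a carboxylic acid or a longer chain at this place would stand nearer compound 1 or compound 3 stays open.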